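Swapping a Nitro Group for tert-Butyl on a Sulfonamide

This account rests on a few compounds, and the source may have more. Where it says the series, first, only, none or still open, it means among the compounds named here.

Compound 1 `O=[N+]([O-])c1ccc(S(=O)(=O)NCCCCCCNCc2ccc(Br)cc2)cc1` and compound 2 `O=S(=O)(NCCCCCCNCc1ccc(Br)cc1)c1cc(Cl)cc(Cl)c1` were both tested in a functional assay on MIA PaCa-2 cells (Homo sapiens) for inhibition, read by MTT assay, with a stated time of 72 h; a higher number here means a weaker inhibitor of growth, a lower number a stronger inhibitor of growth. Compound 1 gives 9800 nM, the low end of the two numbers, and compound 2 gives 12000 nM, the two lying within the scatter of each other, as a 1.2-fold higher number from compound 1 to compound 2 (0.09 log units; within the scatter) shows. Compound 3 `CC(C)(C)c1ccc(S(=O)(=O)NCCCCCCNCc2ccc(Br)cc2)cc1` differs from compound 1 by tert-butyl in place of nitro on an aromatic carbon. Among the compounds with values here, the only measured step touching the ring on the sulfonyl sulfur is that one, and it changed nothing beyond the scatter, so no step beyond the scatter is expected here either. Compound 3 is therefore expected to give 10000 nM, with a range from 4000 nM to 25000 nM. That amounts to an expected step of a 1.0-fold higher number from compound 1 to compound 3 (0.01 log units; within the scatter).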

Compound 3, concentration for 50% growth inhibition: 2970 nM
Estimate against measurement, compound 3: 3.4-fold (0.53 log units) above; measured number below the stated range.
By their numbers in this assay, from the lowest: compound 3; then compounds 1 and 2 (each within the scatter of the next).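

Tert-butyl in place of nitro gives a 3.3-fold lower number from compound 1 to compound 3 (0.52 log units; beyond the scatter) in this assay, the first change shown at this ring position that goes beyond the scatter. The position is therefore not indifferent to what it carries, which the step of a 1.2-fold higher number from compound 1 to compound 2 (0.09 log units; within the scatter) did not reveal. Nothing measured here explains why this swap gives stronger growth inhibition.

As far as these compounds go, whether methyl at this place would match tert-butyl, or an amine or a carboxylic acid would give a weaker inhibitor, remains open. So does whether the step would hold with a longer chain in the shared core.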